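This account rests on a few compounds, and the source may have more. Where it says the series, first, only, none or still open, it means among the compounds named here.

Measured in a physicochemical assay for lipophilicity, read by HPLC, measured as octanol-water partition, at pH 7.4; a higher number here means a more lipophilic compound, a lower number a more polar compound:
- compound 1 `NC(=O)[C@@H](CCC(F)(F)F)N(CC1COC1)S(=O)(=O)c1ccc(Cl)cc1`: 2.5
- compound 2 `CC1(C)C[C@@H](CN([C@H](CCC(F)(F)F)C(N)=O)S(=O)(=O)c2ccc(Cl)cc2)O1`: 3.8
- compound 3 `CC1(C)C[C@H](CN([C@H](CCC(F)(F)F)C(N)=O)S(=O)(=O)c2ccc(Cl)cc2)O1`: 3.8

Compound 1 stands lowest of these three, and compound 2 and compound 3 sit level with each other. The unmeasured compound 4 `NC(=O)[C@@H](CCC(F)(F)F)N(CC1CCCC1)S(=O)(=O)c1ccc(Cl)cc1` departs from compound 1 in a single place, on a saturated chain carbon bound to a sulfonamide nitrogen: cyclopentyl in place of oxetan-3-yl on a saturated chain carbon bound to a sulfonamide nitrogen. Cyclopentyl thus takes the place of oxetan-3-yl.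

The closest evidence comes from two steps that replace the same oxetan-3-yl group, with 4,4-dimethyloxetan-2-yl entering in each. These are a number 1.30 log units higher from compound 1 to compound 2 (beyond the scatter) and a number 1.30 log units higher from compound 1 to compound 3 (beyond the scatter). The stereoisomer pair adds no change at the digits printed from compound 2 to compound 3 (within the scatter), so the configuration at that ring carbon offers no separate guide. The entering cyclopentyl has no hydrogen-bond acceptor, and a rise of similar size or slightly larger in this assay seems likely.

The expected step is a number 1.60 log units higher from compound 1 to compound 4 (beyond the scatter). For compound 4 the estimated value is 4.1, with an expected range from 3.6 to 4.6.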

Compound 4, distribution coefficient: 5.15
For compound 4 the middle estimate is 1.05 log units below the measured one; measured number outside the range, above it.
By their numbers in this assay, from the lowest: compound 1; then compounds 2 and 3 (each within the scatter of the next); then compound 4.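

In this assay, among these compounds, the change at this position reaches further than the earlier compounds showed: a number 2.65 log units higher from compound 1 to compound 4 (beyond the scatter), with cyclopentyl in place of oxetan-3-yl. Compounds carrying 4,4-dimethyloxetan-2-yl also stand well short of compound 4, with a number 1.35 log units higher from compound 2 to compound 4 (beyond the scatter) and a number 1.35 log units higher from compound 3 to compound 4 (beyond the scatter), placing the carbon-only ring beyond both oxetanes on this saturated chain carbon bound to a sulfonamide nitrogen. These last two steps amount to one comparison seen twice, not two independent readings: the fact that compounds 2 and 3 differ only in the configuration as drawn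

The compounds shown do not separate the loss of the ring oxygen from the change in ring size, as cyclopentyl differs from oxetan-3-yl in both. Going by these compounds, how a cyclobutyl group, with its four-membered carbon ring, or a tetrahydrofuran-3-yl group, with its five-membered ring holding oxygen, would read in this assay remains open.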